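The compounds below may be only part of what the source reports. "The series", "measured", "known", "first", "only" and "open" are said of these compounds alone.

Series notes. Compound 1 `Nc1ccccc1NC(=O)/C=C/c1ccc(Cn2cnc3c(Nc4cccc(Cl)c4)nc(Cl)nc32)cc1` was tested in a functional assay on NCI-H460 cells (Homo sapiens) for antiproliferative activity, read by CCK-8 assay, with a stated time of 72 h, tested at 8 uM (on this read-out higher numbers stand for a stronger effect at the one concentration tested and lower numbers for a weaker effect), where compound 1 gives 29.4%. Compound 2 `Nc1ccccc1NC(=O)c1ccc(CNc2nc(Cl)nc3c2ncn3Cc2ccccc2)cc1` in the same assay gives 46.4%, and compound 3 `CC(C)n1cnc2c(Nc3ccccc3)nc(NCOCc3ccc(/C=C/C(=O)Nc4ccccc4N)cc3)nc21` gives 53.1%. Compound 1 thus stands lowest of the three, with its gaps to compound 2 and to compound 3 both beyond the usual scatter of this read-out. Compound 4 `CC1CCN(c2nc(Cl)nc3c2ncn3Cc2ccc(/C=C/C(=O)Nc3ccccc3N)cc2)CC1` has not yet been measured; it differs from compound 1 in one place: 4-methylpiperidin-1-yl in place of (3-chlorophenyl)amino on an aromatic carbon. Going by the values given here, no measured pair shows a change of this kind, so the data give no guide to its effect. The expected step of a number 0.6 percentage points higher from compound 1 to compound 4 (within the scatter) is none beyond the scatter, in either direction. Compound 4 is estimated at 30%, within a range from 15% to 50%.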

Compound 4, a percentage reported as inhibition, at one concentration (the size of the read-out at that concentration, not a potency): 10.8%
Beside the measured number, compound 4's estimate is 19.2 percentage points above it, outside the stated range (below it).
By their numbers in this assay, from the lowest: compound 4; then compound 1; then compounds 2 and 3 (each within the scatter of the next).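

In this assay, the aromatic carbon next to the ring nitrogen responds to the exchange of (3-chlorophenyl)amino for 4-methylpiperidin-1-yl, with a number 18.6 percentage points lower from compound 1 to compound 4 (beyond the scatter). Going by these compounds alone, this is the first read of this position, and it shows that the group here matters to the size of the effect. Nothing available explains the step.

On these data alone, the exchange removes the aromatic ring and the hydrogen-bond donor together, so their shares remain open. A cyclohexylamino group at this carbon would separate the two.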